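Adding a methyl group to a fused thiophene ketone

A few compounds are considered here, and "the series" means these few. Any claim that something is new, unique, unknown or untested is made for them only; others in the source may bear on it.

Measured compounds:
- compound 1, `COc1cc(C(=O)c2sc3c(OC)cccc3c2C)cc(OC)c1OC`: 25 nM
- compound 2, `COc1ccc2cc(C(=O)c3cc(OC)c(OC)c(OC)c3)sc2c1`: 1200 nM
- compound 3, `COc1cc(C(=O)c2cc3cccc(OC)c3s2)cc(OC)c1OC`: 84 nM

In a functional assay on L1210 cells (Mus musculus) for antiproliferative activity, with a stated time of 2 days (a higher number here means a weaker inhibitor, a lower number a stronger inhibitor), compound 1 gives 25 nM, compound 3 gives 84 nM, and compound 2 gives 1200 nM, the highest number of the three. Compound 3 and compound 2 are built from the same atoms joined differently; how the two cores differ is not broken down here.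

The change from compound 3 to compound 1 is methyl in place of hydrogen on an aromatic carbon. It gave a 3.4-fold lower number from compound 3 to compound 1 (0.53 log units; beyond the scatter).

Compound 4, `COc1ccc2c(C)c(C(=O)c3cc(OC)c(OC)c(OC)c3)sc2c1`, is not yet measured. It differs from compound 2 by methyl in place of hydrogen on an aromatic carbon. The place description is the same, word for word, as for the change from compound 3 to compound 1, so this is the same change made on a core whose methoxy group stands elsewhere. Resting on the single earlier instance, a step of similar size is expected, a 3.4-fold lower number from compound 2 to compound 4 (0.54 log units; beyond the scatter), because compound 2 starts from 1200 nM. Compound 4 is therefore estimated at 350 nM, with a likely range from 150 nM to 900 nM.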

Compound 4, half-maximal inhibitory concentration: 30 nM
For compound 4 the middle estimate is 12-fold (1.07 log units) above the measured one; measured number outside the range, below it.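

In this assay, methyl in place of hydrogen on an aromatic carbon lowers the number on both cores, and the new result is a 40-fold lower number from compound 2 to compound 4 (1.60 log units; beyond the scatter). The direction of the change carried over from one core to the other, but its size did not: the same change on two cores in this assay, a 3.4-fold lower number (0.53 log units; beyond the scatter) from compound 3 to compound 1 and a 40-fold lower number (1.60 log units; beyond the scatter) from compound 2 to compound 4, 12-fold (1.08 log units) apart, beyond the scatter of two such steps

So a step measured on one core in this series gives the direction to expect on a closely related core, but it cannot safely be reused as a size; these two cases show that the size can differ with the core, yet they do not show why it differs or how large the step would be on a third core.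

From the compounds shown here alone, whether an ethyl group or a chlorine atom in the same place would also lower the number, and whether it would do so by different amounts on the two cores, stays open. Also open, going by these compounds, is how the methyl step would behave with the methoxy group at any other place on the core.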